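Cyano for hydroxymethyl on the piperidine of compound 2

The compounds below may be only part of what the source reports. "The series", "measured", "known", "first", "only" and "open" are said of these compounds alone.

Working notes on lipophilicity across the series. Compound 1 `N#Cc1cccc(NC(=O)c2cc(C(F)(F)F)ccc2OCc2ccc(F)cc2)c1` gives 7.5 in a physicochemical assay for lipophilicity, at pH 7.4; on this read-out lower numbers stand for lower lipophilicity and higher numbers for higher lipophilicity. Compound 3 `O=C(Nc1cccnc1)c1cc(C(F)(F)F)ccc1OCc1ccccc1` gives 6.3 in this assay. Compound 2 `O=C(Nc1ccnnc1)c1cc(N2CCC(CO)CC2)ccc1OCc1ccccc1` gives 3.5 in this assay, the lowest of the three numbers; compound 3 stands nearest to it, higher by a gap beyond the scatter, and compound 1 stands furthest, higher by a gap that is also beyond the scatter. Within the data shown here, no pair of measured compounds differs in one place only, so these three values are set side by side and not read as steps.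

Compound 4 `N#CC1CCN(c2ccc(OCc3ccccc3)c(C(=O)Nc3ccnnc3)c2)CC1` is not yet measured. It differs from compound 2 as follows: cyano in place of hydroxymethyl on a saturated ring carbon. Among the measured compounds shown here, with no single-change step to lean on, the change is expected to move this assay only a little, upward if at all, and near the scatter. The step from compound 2 to compound 4 is expected to come out at a number 0.40 log units higher from compound 2 to compound 4 (beyond the scatter). Compound 4 is therefore estimated at 3.9, with a range from 3.4 to 4.4.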

Compound 4, distribution coefficient: 4.5
Estimate against measurement, compound 4: 0.60 log units below; the whole stated range lies below it.
By their numbers in this assay, from the lowest: compound 2; then compound 4; then compound 3; then compound 1.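

Among these compounds, this is the first single-change step: in this assay, cyano in place of hydroxymethyl on a saturated ring carbon, three ring bonds from the ring nitrogen, gives a number 1.00 log units higher from compound 2 to compound 4 (beyond the scatter). The earlier compounds shown here differ in more than one place, so they could not isolate a contribution from this position; the change from 4-(hydroxymethyl)piperidin-1-yl to 4-cyanopiperidin-1-yl now shows that this position alone can shift the read-out. The exchange also removes the hydrogen-bond donor and replaces oxygen with nitrogen, but no supporting measurement connects the step to either difference.

Among the compounds shown, this position carries only hydroxymethyl and cyano, so the result with an amine, a carboxylic acid or a longer chain there remains open. On these data alone, whether the same step would appear in a compound with a different amide group also remains open.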